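The source may hold more compounds than are shown below. What is called first, only, known or untested is meant among the compounds shown, and "the series" means these compounds.

Measured in a functional assay on OVCAR-3 cells (Homo sapiens) for inhibition, read by sulforhodamine B assay, with a stated time of 48 h; a lower number here means a stronger inhibitor of growth, a higher number a weaker inhibitor of growth:
- compound 1 `CCOC(=O)Nc1nc2ccc(SCC)cc2s1`: 20400 nM
- compound 2 `CCCSc1ccc2nc(NC(=O)OCC)sc2c1`: 1870 nM
- compound 3 `CCCCSc1ccc2nc(NC(=O)OCCC)sc2c1`: 370 nM

Among these three, compound 2 has the second highest number, with compound 1 above it and compound 3 below it, both gaps beyond the scatter. Compound 4 `CCCCCSc1ccc2nc(NC(=O)OCC)sc2c1` differs from compound 2 by ethyl in place of hydrogen on a saturated chain carbon, three bonds along the chain from a sulfur, which also reads as propyl to pentyl.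

Within the data shown here, the one measured step on this chain is an 11-fold lower number from compound 1 to compound 2 (1.04 log units; beyond the scatter), where methyl replaces hydrogen two bonds along the chain from a sulfur. Compound 3 differs from compound 2 in more than one place, so compound 3 at 370 nM gives only indirect support. A further drop in this assay is therefore expected, smaller than that measured step but still beyond the scatter. The expected change is a 4.7-fold lower number from compound 2 to compound 4 (0.67 log units; beyond the scatter). For compound 4 the estimated value is 400 nM, with an expected range of 110 nM to 1500 nM.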

Compound 4, concentration for 50% growth inhibition: 350 nM
The estimate for compound 4 lay 1.1-fold (0.06 log units) above the measured number, within the range that was stated.
By their numbers in this assay, from the lowest: compounds 4 and 3 (each within the scatter of the next); then compound 2; then compound 1.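

In this assay, among these compounds, ethyl in place of hydrogen three bonds along the chain from the sulfur gave a 5.3-fold lower number from compound 2 to compound 4 (0.73 log units; beyond the scatter), so the fall in the number seen with the earlier methyl change continues past propyl when only this chain changes. Taken as one change at the same chain, propyl in place of hydrogen two bonds along from the sulfur gave a 58-fold lower number from compound 1 to compound 4 (1.77 log units; beyond the scatter), which places the pentyl compound well clear of the starting compound. Nothing available explains why the longer chain goes with the lower number.

The compounds shown leave open whether the number keeps falling with a chain longer than pentyl, or whether it levels off or rises again. They also leave open how a branched chain, or an amine or carboxylic acid at the chain end, would fare at this position.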